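The source may report more compounds than this note shows. Statements on the series, on what has been measured and on what is new or still open speak of the compounds shown alone.

Compound 1, with structure `CS/C(=N\C(=O)c1ccco1)NC(=O)c1ccco1`, compound 3, with structure `CS/C(=N\C(=O)c1cc(-c2ccccc2)nc2ccccc12)NC(=O)c1cc(-c2ccccc2)nc2ccccc12`, and compound 2, with structure `O=C(/N=C(/NC(=O)c1cc(-c2ccccc2)nc2ccccc12)[Se]Cc1ccccc1)c1cc(-c2ccccc2)nc2ccccc12`, were tested in a functional assay on MCF7 cells (Homo sapiens) for cytotoxicity, read by MTT assay, with a stated time of 72 h; on this read-out lower numbers stand for stronger inhibition of growth and higher numbers for weaker inhibition of growth. In this assay compound 1 gives only a limit, > 100000 nM, and not a number. Compound 3 gives 87700 nM in this assay, and compound 2 gives 45600 nM. Compound 2 differs from compound 3 by a group of 8 heavy atoms (7 carbon, 1 selenium; one six-membered aromatic ring of carbon only) in place of a group of 2 heavy atoms (1 carbon, 1 sulfur; no ring), on a carbon with a double bond to nitrogen, and this change made a step of a 1.9-fold lower number from compound 3 to compound 2 (0.28 log units; within the scatter). The difference between the cores of compound 1 and compound 3 is not broken down here. Compound 4, with structure `O=C(/N=C(/NC(=O)c1ccco1)[Se]Cc1ccccc1)c1ccco1`, has not yet been measured in this assay. It differs from compound 1 by a group of 8 heavy atoms (7 carbon, 1 selenium; one six-membered aromatic ring of carbon only) in place of a group of 2 heavy atoms (1 carbon, 1 sulfur; no ring), on a carbon with a double bond to nitrogen, the same change that was made on the core of compound 3 to give compound 2. Because the same change gave the step of a 1.9-fold lower number from compound 3 to compound 2 (0.28 log units; within the scatter), a step of similar size is expected here as well, so compound 4 is expected to show an at least 1.1-fold lower number from compound 1 to compound 4 (0.04 log units; that floor lies within the scatter). Because compound 1 stands at the limit (the limit of > 100000 nM in this assay, at which 1 of the 3 values shown sits), compound 4 may also be reported only as a limit. The estimate for compound 4 in this assay is 90000 nM, within 40000 nM to 200000 nM.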

Compound 4, concentration for total growth inhibition: 58000 nM
Estimate against measurement, compound 4: 1.6-fold (0.19 log units) above, and the stated range covers the measured number.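

In this assay, putting the selenium-bearing group with its aromatic ring in place of methylsulfanyl, on a carbon with a double bond to nitrogen, gives an at least 1.7-fold lower number from compound 1 to compound 4 (0.23 log units; that floor lies within the scatter). Set beside the earlier step, the result is compatible with the change carrying over from one core to the other, though no exact comparison is possible: the same change on two cores in this assay, a 1.9-fold lower number (0.28 log units; within the scatter) from compound 3 to compound 2 and an at least 1.7-fold lower number (0.23 log units; that floor lies within the scatter) from compound 1 to compound 4; the limit leaves it open whether they differ. It does not show a firm gain on either core, as the earlier step and the floor of the new one both lie within the usual scatter, and the value that anchors the new step is only a limit: the limit of > 100000 nM in this assay, at which 1 of the 4 values shown sits.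

The compounds shown leave open whether the selenium or the aromatic ring matters more, for the two enter together in both steps. They also leave open how an amine or a longer chain on the same carbon would read in this assay.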